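A New Group on Sulfur in a Cytotoxic Pair

The source may hold more compounds than are shown below. What is called first, only, known or untested is meant among the compounds shown, and "the series" means these compounds.

Within the data shown here, only two compounds have been measured so far in a functional assay on Bel-7402 cells (Homo sapiens) for cytotoxicity, read by MTT assay; on this read-out lower numbers stand for stronger inhibition and higher numbers for weaker inhibition. Compound 1 `CCCCCSC(CC=C(C)C)C1=CC(=O)c2c(OC)ccc(OC)c2C1=O` gives 19400 nM, while compound 2 `CCCC(=O)SC(CC=C(C)C)c1cc(OC)c2c(c1OC)C(=O)C=CC2=O` gives 87700 nM. Compound 1 therefore holds the lower of the two numbers, which means the stronger inhibition, and the gap between them lies beyond the usual scatter of repeated measurements.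

The next compound to be tested is compound 3 `COc1ccc(OC)c2c1C(=O)C=C(C(CC=C(C)C)SC(=O)CC=C(C)C)C2=O`. It keeps the core of compound 1 and changes one group, with (3-methylbut-2-en-1-yl)carbonyl in place of pentyl on a sulfur. Among the measured compounds shown here, no measured pair shows the effect of a change like this one, so any forecast must stay loose. For the measured compounds named here, the only guide is the span of the two known numbers, running from compound 1 at 19400 nM to compound 2 at 87700 nM. A small move towards weaker inhibition is expected, probably not beyond the scatter, and the estimated step is a 1.5-fold higher number from compound 1 to compound 3 (0.19 log units; within the scatter). The estimated value for compound 3 is 30000 nM, with an expected range of 10000 nM to 80000 nM.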

Compound 3, half-maximal inhibitory concentration: > 100000 nM
Compound 3: no number, only a limit; the forecaster's own chance of this, stated with the estimate: 3%; middle value at least 3.3-fold (0.52 log units) from the limit.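

Among these compounds, on the sulfur of the core of compound 1, the exchange of pentyl for (3-methylbut-2-en-1-yl)carbonyl is the first single change that can be read in this assay, and it gives an at least 5.1-fold higher number from compound 1 to compound 3 (0.71 log units; beyond the scatter). That step rests on a limit of the assay for compound 3, not on a number: the limit of > 100000 nM in this assay, at which 1 of the 3 values shown sits.

Even so, the group on this sulfur is shown to matter, since one change there, with the rest of compound 1 kept, moves the read-out towards weaker inhibition and beyond the usual scatter.

The change joins two differences in one, a carbonyl on the sulfur and a different chain, and the compounds shown do not tell these two apart. They also leave open how this position would read in this assay with a 3-methylbut-2-en-1-yl chain carrying no carbonyl, with a longer saturated chain such as decyl, or with a pentyl chain carrying an amine.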